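Trading hydroxy for methyl on a growth inhibitor

The compounds below may be only part of what the source reports. "The series", "measured", "known", "first", "only" and "open" are said of these compounds alone.

Compound 1 `Cc1ccc2[nH]c(-c3ccc(-c4ccc(-c5ccc(N(C)C)cc5)cc4)cc3)nc2c1` gives 6240 nM
Compound 2 `Oc1cccc2[nH]c(-c3ccc(-c4ccc(-c5ccc(C(F)(F)F)cc5)cc4)cc3)nc12` gives 3190 nM

In a functional assay on Gurav cells (Homo sapiens) for inhibition, read by sulforhodamine B assay (on this read-out higher numbers stand for weaker inhibition of growth and lower numbers for stronger inhibition of growth), compound 2 gives 3190 nM and compound 1 gives 6240 nM and the two values lie within the usual scatter of each other. Compound 2 therefore holds no firm place relative to compound 1.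

Compound 3 `Cc1ccc2[nH]c(-c3ccc(-c4ccc(-c5ccc(C(F)(F)F)cc5)cc4)cc3)nc2c1` keeps the trifluoromethyl group of compound 2 and carries 5-methyl-1H-benzimidazol-2-yl in place of 4-hydroxy-1H-benzimidazol-2-yl on an aromatic carbon. Within the data shown here, no measured pair shows this change on its own, so any forecast rests on thin evidence. The same 5-methyl-1H-benzimidazol-2-yl is already present in compound 1, and compound 2 stays close to compound 1 at 6240 nM in the same test. In this assay no step beyond the scatter is therefore expected, with at most a slight drift toward higher numbers. The estimated step (a 1.3-fold higher number from compound 2 to compound 3 (0.10 log units; within the scatter)) stays small. For compound 3 the expected value is 4000 nM within an estimated range of 1500 nM to 10000 nM as the likely span.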

Compound 3, concentration for 50% growth inhibition: 12000 nM
Beside the measured number, compound 3's estimate is 3.0-fold (0.48 log units) below it; measured number above the stated range.
By their numbers in this assay, from the lowest: compounds 2, 1 and 3 (each within the scatter of the next, the first and the last beyond it).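

Among these compounds, with trifluoromethyl held constant, the exchange of 4-hydroxy-1H-benzimidazol-2-yl for 5-methyl-1H-benzimidazol-2-yl gives in this assay a 3.8-fold higher number from compound 2 to compound 3 (0.58 log units; beyond the scatter) and so provides the first comparison at this position, a modest step that lies beyond the scatter. With 5-methyl-1H-benzimidazol-2-yl held constant, the exchange of dimethylamino for trifluoromethyl gives a 1.9-fold higher number from compound 1 to compound 3 (0.28 log units; within the scatter) and so shows no firm effect of that exchange in this assay. No supporting measurement on hand bears on the origin of the step from the hydroxy-bearing group to the methyl-bearing group.

The compounds shown do not separate the loss of the hydroxy group from the gain of the methyl group, as the one step carries both at once. Also open, as far as these compounds go, is how an amino or methoxy group on that ring system would compare, and whether 4-hydroxy-1H-benzimidazol-2-yl paired with dimethylamino would show a step of similar size.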